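Bromo on the fused ring of the benzimidazole aniline series

This account rests on a few compounds, and the source may have more. Where it says the series, first, only, none or still open, it means among the compounds named here.

Measured so far in a functional assay on the whole organism (strain albino) for inhibition, with Rattus norvegicus as the target, read by paw edema, with a stated time of 120 min, at a dose of 100 mg/kg by the oral route; on this read-out lower numbers stand for less inhibition and higher numbers for more inhibition at the one dose given (going by the name of the read-out):
- compound 1, `Clc1cccc(NCc2nc3ccccc3[nH]2)c1`: compound 1 gives 41.1%
- compound 2, `c1ccc(NCc2nc3ccccc3[nH]2)cc1`: compound 2 gives 41.1%

Compound 1 stands level with compound 2 at the digits shown; the one measured step, no change at the digits printed from compound 1 to compound 2 (within the scatter), is within the scatter and concerns the chloro on the aniline ring, hydrogen in place of chloro on an aromatic carbon.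

Compound 3, `Clc1cccc(NCc2nc3ccc(Br)cc3[nH]2)c1`, is not yet measured. It differs from compound 1 by bromo in place of hydrogen on an aromatic carbon; the change sits on the fused ring of the shared core, not on the aniline ring. Within the data shown here, no measured step touches that ring, so the only guidance is that the one step seen, removing the chloro, produced no change beyond the scatter. The expected step is therefore none beyond the scatter, a number 0.1 percentage points lower from compound 1 to compound 3 (within the scatter). In this assay compound 3 is estimated at 41%, with a range from 28% to 54%.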

Compound 3, a percentage reported as inhibition, in the whole organism at one dose (the size of the read-out at that dose, not a potency): 17.6%
Estimate against measurement, compound 3: 23.4 percentage points above; the whole stated range lies above it.
By their numbers in this assay, from the lowest: compound 3; then compounds 1 and 2 (each within the scatter of the next).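

In this assay, among these compounds, the fused ring of the shared core is the first place where a single change moves the read-out: bromo in place of hydrogen on an aromatic carbon of that ring gives a number 23.5 percentage points lower from compound 1 to compound 3 (beyond the scatter) and so less inhibition at the one dose given. Among the compounds shown here, the only earlier step, on the aniline ring, showed no change at the digits printed from compound 1 to compound 2 (within the scatter) and gave no sign that the read-out would respond to a change at this place. Nothing on hand explains the loss.

The compounds shown leave open whether the loss is tied to bromo itself or would also follow from a smaller halogen such as fluoro, or from a methoxy group or a carboxylic acid at the same carbon. Also open, from the compounds shown here alone, is whether bromo would act the same way on the core of compound 2, which has no chloro on its aniline ring.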